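Furan-2-yl in place of quinolin-4-yl

The source may hold more compounds than are shown below. What is called first, only, known or untested is meant among the compounds shown, and "the series" means these compounds.

In an ADME assay on CCRF-CEM cells (Homo sapiens) for cytotoxicity, read by MTT assay, with a stated time of 72 h (a higher number here means that more compound is tolerated, a lower number that less compound is tolerated), compound 1 (`CC(=O)c1c(O)c(C(C)=O)c(O)c(C(c2c(O)c(C(C)=O)c(O)c(C(C)=O)c2O)C2CCCCC2)c1O`) gives 58900 nM and compound 2 (`CC(=O)c1c(O)c(C(C)=O)c(O)c(C(c2c(O)c(C(C)=O)c(O)c(C(C)=O)c2O)c2ccnc3ccccc23)c1O`) gives 93400 nM. Among the compounds with values here, compound 2 thus stands level with compound 1, the only other compound measured, since the two numbers lie within the usual scatter of each other. Compound 3 (`CC(=O)c1c(O)c(C(C)=O)c(O)c(C(c2ccco2)c2c(O)c(C(C)=O)c(O)c(C(C)=O)c2O)c1O`) has not yet been measured. The structural change is furan-2-yl in place of quinolin-4-yl on a saturated chain carbon bound to two aromatic carbons, which amounts to furan-2-yl in place of quinolin-4-yl on a saturated chain carbon bound to two aromatic carbons. Within the data shown here, only one measured step bears on this change, and it sits at the same carbon, where quinolin-4-yl replaced cyclohexyl: a 1.6-fold higher number from compound 1 to compound 2 (0.20 log units; within the scatter). That single step stayed within the scatter, although the two groups are very different. Among the measured compounds shown here, no measured compound carries furan-2-yl, so the guide is thin, and no step beyond the scatter is expected in this assay. The estimated change is a 1.2-fold lower number from compound 2 to compound 3 (0.10 log units; within the scatter). For compound 3 the estimated value is 75000 nM, with an expected range from 35000 nM to 150000 nM.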

Compound 3, half-maximal cytotoxic concentration: 61200 nM
For compound 3 the middle estimate is 1.2-fold (0.09 log units) above the measured one, and the stated range covers the measured number.
By their numbers in this assay, from the lowest: compounds 1, 3 and 2 (each within the scatter of the next).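

In this assay, furan-2-yl in place of quinolin-4-yl on a saturated chain carbon bound to two aromatic carbons gives a 1.5-fold lower number from compound 2 to compound 3 (0.18 log units; within the scatter), so a group of 5 heavy atoms with one five-membered aromatic ring stands level with one of 10 heavy atoms with two six-membered aromatic rings. Within the data shown here, the step that links the two ends of the series, furan-2-yl in place of cyclohexyl at the same place, gives a 1.0-fold higher number from compound 1 to compound 3 (0.02 log units; within the scatter), and with it all three pairs among compound 1, compound 2 and compound 3 are now seen to lie within the scatter, so this place has tolerated a saturated ring, a fused aromatic pair and a small aromatic ring with no step that can be told from noise. Nothing available explains why the number stays level across these groups.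

Whether an amine or a carboxylic acid on this carbon would produce a step beyond the scatter remains open, since all three groups shown carry no net charge. The core is also the same in all three compounds, so what its acetyl and hydroxyl groups contribute to these numbers cannot be told from them.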